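The compounds below may be only part of what the source reports. "The series", "measured", "known", "first", "only" and "open" are said of these compounds alone.

Measured compounds:
- compound 1, `Cc1cc(=O)n(-c2ccccc2C(F)(F)F)nc1C(=O)Nc1ccc(Oc2ncnc3ccsc23)c(F)c1`: 6020 nM
- compound 2, `Cc1cc(=O)n(-c2cccc(F)c2)nc1C(=O)Nc1ccc(Oc2ncnc3ccsc23)c(F)c1`: 9050 nM

Two compounds share one core and differ only in the aromatic group on a ring nitrogen. In a functional assay on MCF7 cells (Homo sapiens) for cytotoxicity, read by MTT assay, with a stated time of 72 h (a higher number here means a weaker inhibitor, a lower number a stronger inhibitor), compound 1 gives 6020 nM, and compound 2 gives 9050 nM. Compound 2 holds the highest of the two numbers, but the step of a 1.5-fold higher number from compound 1 to compound 2 (0.18 log units; within the scatter) is within the scatter, so the two compounds cannot be told apart on these data.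

Compound 3, `Cc1ccc(-n2nc(C(=O)Nc3ccc(Oc4ncnc5ccsc45)c(F)c3)c(C)cc2=O)cc1`, is not yet measured. It differs from compound 2 in one place: 4-methylphenyl in place of 3-fluorophenyl on an aromatic nitrogen. Among the compounds with values here, the only step that bears on this change is the one from compound 1 to compound 2, which also exchanged the aromatic group on that nitrogen and gave a 1.5-fold higher number from compound 1 to compound 2 (0.18 log units; within the scatter). One such exchange with no effect beyond the scatter is thin ground, but it is all there is, and nothing in it points in either direction. The expectation for compound 3 is therefore a step of about a 1.1-fold lower number from compound 2 to compound 3 (0.03 log units; within the scatter), not beyond the scatter. Compound 3 is estimated at 8500 nM, with a range from 3000 nM to 25000 nM.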

Compound 3, half-maximal inhibitory concentration: 7250 nM
For compound 3 the middle estimate is 1.2-fold (0.07 log units) above the measured one; the measured number falls inside the stated range.
By their numbers in this assay, from the lowest: compounds 1, 3 and 2 (each within the scatter of the next).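

In this assay, 4-methylphenyl in place of 3-fluorophenyl on the aromatic nitrogen gives a 1.2-fold lower number from compound 2 to compound 3 (0.10 log units; within the scatter) and, set against the other measured compound, gives a 1.2-fold higher number from compound 1 to compound 3 (0.08 log units; within the scatter) as well. A third aromatic group at this position, now carrying a methyl group instead of fluorine or trifluoromethyl, therefore leaves all three compounds indistinguishable, so among these three substituted phenyl groups the choice of group makes no difference that this assay can resolve. No measurement beyond these numbers speaks to a cause for this.

As far as these compounds go, all three groups are substituted phenyl rings, so it remains open whether something of a different kind on this nitrogen, such as an unsubstituted phenyl, a pyridine ring, a phenyl bearing an amine or a carboxylic acid, or a plain butyl chain, would move the number beyond the scatter. From the compounds shown here alone, the methyl group and the fluorine of the shared core are the same in all three compounds, so what each of them contributes also remains open.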